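The source may report more compounds than this note shows. Statements on the series, on what has been measured and on what is new or still open speak of the compounds shown alone.

Compound 1 `COc1ccc2occ(CSC(=S)N(C(C)C)C(C)C)c(=O)c2c1` carries a diisopropylamino group on a thiocarbonyl carbon, and in a functional assay on HeLa cells (Homo sapiens) for antiproliferative activity, read by MTT assay, with a stated time of 72 h (a higher number here means a weaker inhibitor, a lower number a stronger inhibitor), compound 1 gives 5400 nM. Compound 3 `COc1ccc2oc(CSC(=S)N(C(C)C)C(C)C)cc(=O)c2c1` is built from the same atoms joined differently; how the two cores differ is not broken down here. In this assay compound 3 gives > 25000 nM, which is a limit of the assay and not a number. Compound 2 `COc1ccc2oc(CSC(=S)N3CCOCC3)cc(=O)c2c1` differs from compound 3 by morpholin-4-yl in place of diisopropylamino on a thiocarbonyl carbon. In this assay compound 2 gives > 25000 nM, again a limit and not a number. The step that the two limits leave unreadable from compound 3 to compound 2 therefore has no readable size because of the limit of > 25000 nM in this assay, at which 2 of the 3 values shown sit. Compound 4 `COc1ccc2occ(CSC(=S)N3CCOCC3)c(=O)c2c1`, not yet measured, differs from compound 1 by morpholin-4-yl in place of diisopropylamino on a thiocarbonyl carbon, the same change made on the core of compound 1. Among the compounds with values here, since the only measured instance of this change gives no readable size, the expectation for compound 4 rests on compound 1 alone, whose 5400 nM is the only number among the three. The step from compound 1 to compound 4 is expected to be modest, a 1.5-fold higher number from compound 1 to compound 4 (0.17 log units; within the scatter). Compound 4 is thus estimated at 8000 nM, with a range from 3000 nM to 25000 nM.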

Compound 4, half-maximal inhibitory concentration: 9500 nM
Compound 4: the middle estimate sits 1.2-fold (0.07 log units) below what was measured, and the stated range covers the measured number.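

In this assay, placing morpholin-4-yl in place of diisopropylamino on a thiocarbonyl carbon on the core of compound 1 gives a 1.8-fold higher number from compound 1 to compound 4 (0.25 log units; within the scatter), so on this core the change stays within the scatter. This is a single readable instance and sets no rule for the series, since it shows what the change does on one core only. On the core shared by compound 3 and compound 2 the same change cannot be read, and whether the size carries from one core to the other stays unknown because both of those values are limits and not numbers: the limit of > 25000 nM in this assay, at which 2 of the 4 values shown sit.

The compounds shown leave open how other amines on the thiocarbonyl carbon, such as piperidin-1-yl or dimethylamino, would read on the core of compound 1. They also leave open whether any such amine on the core of compound 3 would give a readable number in this assay.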